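The source may report more compounds than this note shows. Statements on the series, on what has been measured and on what is new or still open speak of the compounds shown alone.

Measured in an ADME assay on HepG2 cells (Homo sapiens) for cytotoxicity; a lower number here means that less compound is needed, a higher number that more compound is needed for the effect:
- Compound 1 `Cc1ccc(S(=O)(=O)N[C@@H](CC(=O)NC(C)(C)C)C(=O)NCCNC(=O)c2ccccc2Cl)cc1`: > 11000 nM, a limit of the assay
- Compound 2 `Cc1ccc(S(=O)(=O)N[C@@H](CC(=O)NC(C)(C)C)C(=O)NCCNS(=O)(=O)c2ccccc2)cc1`: > 11000 nM, a limit of the assay

Compound 2 has no exact number in this assay, only its limit of > 11000 nM. Both measured compounds share this position: the limit of > 11000 nM in this assay, at which 2 of the 2 values shown sit.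

Compound 3 `Cc1ccc(S(=O)(=O)N[C@@H](CC(=O)NC(C)(C)C)C(=O)NCCNC(=O)c2ccccc2O)cc1` carries (2-hydroxyphenyl)carbonyl in place of phenylsulfonyl on an amine nitrogen.

Within the data shown here, the only measured change on that nitrogen is a step that the two limits leave unreadable from compound 1 to compound 2, so it offers no size to build on. No clear step in either direction is expected, and the assay will probably report a limit again. The expected change is a step that the limit leaves unreadable from compound 2 to compound 3. For compound 3 the estimated value is 14000 nM, with an expected range of 7000 nM to 40000 nM.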

Compound 3, half-maximal effective concentration: > 11000 nM
Compound 3: no number, only a limit; the forecaster's own chance of this, stated with the estimate: 85%; the middle value lies beyond the limit too.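

No step can be read among compound 1, compound 2 and compound 3, because all three give only a limit of the assay: the limit of > 11000 nM in this assay, at which 3 of the 3 values shown sit.

Still open, from the compounds shown here alone, is whether any group on that amine nitrogen would give an exact number in this assay.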